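Cyanophenyl for bromofluorophenyl on a pyridin-4-yl core

The compounds below may be only part of what the source reports. "The series", "measured", "known", "first", "only" and "open" are said of these compounds alone.

Of the compounds shown here, three of one shared core have been tested in a functional assay on HepG2 cells (Homo sapiens) for cytotoxicity, read by MTT assay, with a stated time of 24 h; on this read-out higher numbers stand for weaker inhibition and lower numbers for stronger inhibition. Compound 1 `CN1C/C(=C\c2cccnc2)C(=O)/C(=C/c2ccc(F)cc2Br)C1` gives 13000 nM. Compound 2 `CN1C/C(=C\c2ccc(C#N)cc2)C(=O)/C(=C/c2cccnc2)C1` gives 12700 nM. Compound 3 `CN1C/C(=C\c2ccncc2)C(=O)/C(=C/c2ccc(F)cc2Br)C1` gives 9200 nM. Among the compounds with values here, compound 3 stands with the smallest of the three numbers, yet its gap to compound 2 and to compound 1 lies within the scatter, so no compound can be called more or less active than another on this assay.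

Compound 4 `CN1C/C(=C\c2ccncc2)C(=O)/C(=C/c2ccc(C#N)cc2)C1` has not been measured. It differs from compound 3 in one place: 4-cyanophenyl in place of 2-bromo-4-fluorophenyl on a double-bonded chain carbon bound to a double-bonded ring carbon. The same exchange has already been seen once, on the pyridin-3-yl branch of the core, as a 1.0-fold lower number from compound 1 to compound 2 (0.01 log units; within the scatter). The other step, a 1.4-fold lower number from compound 1 to compound 3 (0.15 log units; within the scatter), concerns the pyridine and is likewise within the scatter. Nothing here suggests that the cyanophenyl exchange moves the number, so on this assay compound 4 is expected to sit close to compound 3, with an expected step of a 1.0-fold higher number from compound 3 to compound 4 (0.01 log units; within the scatter). Compound 4 is therefore estimated at 9500 nM, within 4500 nM to 20000 nM.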

Compound 4, half-maximal inhibitory concentration: 13900 nM
Estimate against measurement, compound 4: 1.5-fold (0.17 log units) below, within the range that was stated.
By their numbers in this assay, from the lowest: compounds 3, 2, 1 and 4 (each within the scatter of the next).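

In this assay the 4-cyanophenyl exchange has now been read on both the pyridin-3-yl and the pyridin-4-yl branches of the shared core, and on the latter it gives a 1.5-fold higher number from compound 3 to compound 4 (0.18 log units; within the scatter). So the earlier absence of a clear shift is not confined to one branch, as the two readings agree: the same change on two cores in this assay, a 1.0-fold lower number (0.01 log units; within the scatter) from compound 1 to compound 2 and a 1.5-fold higher number (0.18 log units; within the scatter) from compound 3 to compound 4, 1.5-fold (0.19 log units) apart, within the scatter of two such steps. The pyridine exchange, earlier read only with 2-bromo-4-fluorophenyl, now gives a 1.1-fold higher number from compound 2 to compound 4 (0.04 log units; within the scatter) with 4-cyanophenyl, and it too holds on both: the same change on two cores in this assay, a 1.4-fold lower number (0.15 log units; within the scatter) from compound 1 to compound 3 and a 1.1-fold higher number (0.04 log units; within the scatter) from compound 2 to compound 4, 1.5-fold (0.19 log units) apart, within the scatter of two such steps.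

The four compounds therefore show no group at either place that separates one compound from another on this read-out. From the compounds shown here alone, whether an amine or a carboxylic acid on a double-bonded chain carbon bound to a double-bonded ring carbon would give a step beyond the scatter stays open.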